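A Cyano Group in Place of the Ester-Bearing Chain

The source may report more compounds than this note shows. Statements on the series, on what has been measured and on what is new or still open speak of the compounds shown alone.

compound 1, `CCN(CC)c1ccc2cc(C(=O)c3ccc(N4CCN(C(=O)CN5CCN(S(=O)(=O)c6ccc(F)cc6)CC5)CC4)cc3)oc2c1`: in a functional assay on HCT-116 cells (Homo sapiens) for cytotoxicity, read by MTT assay, with a stated time of 48 h (on this read-out higher numbers stand for weaker inhibition and lower numbers for stronger inhibition), compound 1 gives only a limit, > 40000 nM.
compound 2, `CCN(CC)c1ccc2cc(C(=O)c3ccc(N4CCN(C(=O)CN5CCN(Cc6ccc(/C=C/C(=O)OC)cc6)CC5)CC4)cc3)oc2c1`: in this assay compound 2 gives 9920 nM.

Among the compounds with values here, compound 2 therefore holds the only actual number here, while compound 1 sits at the limit of the assay (the limit of > 40000 nM in this assay, at which 1 of the 2 values shown sits). Compound 3, `CCN(CC)c1ccc2cc(C(=O)c3ccc(N4CCN(C(=O)CN5CCN(Cc6ccc(C#N)cc6)CC5)CC4)cc3)oc2c1`, differs from compound 2 in a single place: cyano in place of 2-(methoxycarbonyl)ethenyl on an aromatic carbon. Within the data shown here, no step between two measured compounds is available, so there is no measured guide for what such a swap does in this assay. The change is expected to move the value only a little, within the ordinary scatter of repeated measurements, and the expected step is a 1.1-fold higher number from compound 2 to compound 3 (0.04 log units; within the scatter). Compound 3 is thus estimated to give about 11000 nM in this assay, with a likely range from 4000 nM to 32000 nM.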

Compound 3, half-maximal inhibitory concentration: > 40000 nM
Compound 3 ended at the assay's limit; the forecaster's own chance of this, stated with the estimate: 15%; at least 3.6-fold (0.56 log units) between middle value and limit.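

On this aromatic carbon, para to a large group, the substituent clearly matters: in this assay, cyano in place of 2-(methoxycarbonyl)ethenyl brings an at least 4.0-fold higher number from compound 2 to compound 3 (0.60 log units; beyond the scatter). Within the data shown here, this is the first measured step at this position, and it shows that 4-cyanophenyl cannot stand in for 4-(2-(methoxycarbonyl)ethenyl)phenyl while the rest of the molecule stays the same. Compound 3 gives a limit rather than a number, so the step sets only a minimum size: the limit of > 40000 nM in this assay, at which 2 of the 3 values shown sit.

The step from compound 1 to compound 3 joins two limits and cannot be read. The compounds shown also leave open whether the activity of compound 2 depends on the ester, the double bond or simply the longer chain, a question that a carboxylic acid or an amide at this position could help to answer.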